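A Methoxy Group Replaces the Chlorophenyl of Compound 3

A few compounds are considered here, and "the series" means these few. Any claim that something is new, unique, unknown or untested is made for them only; others in the source may bear on it.

Of the compounds shown here, three sharing one core have been measured in a functional assay on OVCAR-3 cells (Homo sapiens) for inhibition, read by MTT assay, with a stated time of 24 h; on this read-out higher numbers stand for weaker inhibition and lower numbers for stronger inhibition. Compound 1 (`CC1(C)[C@H]2CC[C@]1(C)N(Cc1cn(-c3ccc(C#N)cc3)nn1)C(=O)C2`) gives 380 nM, compound 2 (`CC1(C)[C@H]2CC[C@]1(C)N(Cc1cn(-c3cccc(O)c3)nn1)C(=O)C2`) gives 370 nM, and compound 3 (`CC1(C)[C@H]2CC[C@]1(C)N(Cc1cn(-c3ccc(Cl)cc3)nn1)C(=O)C2`) gives 160 nM, the lowest number of the three and so the strongest inhibition. The unmeasured compound 4 (`COc1cccc(-n2cc(CN3C(=O)C[C@@H]4CC[C@@]3(C)C4(C)C)nn2)c1`) carries 3-methoxyphenyl in place of 4-chlorophenyl on an aromatic nitrogen.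

Going by the values given here, no measured compound carries 3-methoxyphenyl, so the evidence is indirect. The closest guide is the 3-hydroxyphenyl of compound 2, with a modest 2.3-fold lower number from compound 2 to compound 3 (0.36 log units; beyond the scatter). Replacing the chloro group with cyano gives a similar gap, a 2.4-fold lower number from compound 1 to compound 3 (0.38 log units; beyond the scatter), while a 1.0-fold lower number from compound 1 to compound 2 (0.01 log units; within the scatter) shows no separation between the two compounds without chlorine. Leaving 4-chlorophenyl is therefore expected to raise the number modestly, meaning weaker inhibition. The expected change is a 1.9-fold higher number from compound 3 to compound 4 (0.27 log units; within the scatter). For compound 4, the estimated value is 300 nM, with an expected range from 140 nM to 620 nM.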

Compound 4, half-maximal inhibitory concentration: 280 nM
Estimate against measurement, compound 4: 1.1-fold (0.03 log units) above; the range from low to high includes it.
By their numbers in this assay, from the lowest: compounds 3, 4, 2 and 1 (each within the scatter of the next, the first and the last beyond it).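

In this assay, putting a methyl on the oxygen of compound 2 gives a 1.3-fold lower number from compound 2 to compound 4 (0.12 log units; within the scatter) and so leaves no separation from the free hydroxyl on this ring. Compound 4 also cannot be separated from its chlorine-bearing neighbour, with a 1.8-fold higher number from compound 3 to compound 4 (0.24 log units; within the scatter) as the step, or from its nitrile-bearing neighbour, with a 1.4-fold lower number from compound 1 to compound 4 (0.13 log units; within the scatter) as the step, even though those two neighbours stand apart from each other. Nothing here beyond these potency numbers helps to explain them.

The swap from 4-chlorophenyl to 3-methoxyphenyl changes both the group and its place on the ring, so 3-chlorophenyl and 4-methoxyphenyl would be needed to separate those two changes. From the compounds shown here alone, it also remains open whether a longer chain on the oxygen, such as ethoxy, or an amine at this place on the ring would shift the number beyond the scatter.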